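The source may report more compounds than this note shows. Statements on the series, on what has been measured and on what is new or still open speak of the compounds shown alone.

Compound 1, `O=C(NCCCCc1ccccc1)n1cnc2ccccc21`, in a physicochemical assay for metabolic stability, read by HPLC, at pH 4.5, tested at 10 uM; on this read-out lower numbers stand for a shorter-lived compound and higher numbers for a longer-lived compound: > 2 h, which is a limit of the assay (the limit of > 2 h in this assay, at which 1 of the 3 values shown sits).
Compound 2, `Cc1cccc(CNC(=O)n2c(N)nc3ccccc32)c1`, in this assay: 0.45 h.
Compound 3, `Cc1nc2ccccc2n1C(=O)NCCCCc1ccccc1`, in this assay: 0.133 h.

Among the two numbers given, compound 2 gives the higher; compound 3 lies a good deal lower. Compound 1 and compound 3 differ in one place, (hydrogen in place of methyl on an aromatic carbon), and this change gave an at least 15-fold higher number from compound 3 to compound 1 (1.17 log units; beyond the scatter). How the core of compound 2 differs from that of compound 3 is not broken down here.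

Compound 4, `Nc1nc2ccccc2n1C(=O)NCc1ccccc1`, is not yet measured. It differs from compound 2 by hydrogen in place of methyl on an aromatic carbon. This is the same kind of change as that from compound 3 to compound 1, but not the same: there the place was on a five-membered aromatic ring with 2 nitrogen, part of a fused or bridged system of two rings, between two ring nitrogen atoms, next to the ring atom that bears a large group; here it is on a six-membered aromatic ring of carbon only, meta to a large group.

With the place so different, a smaller step is expected in this assay; for compound 4 the estimate is a 1.1-fold higher number from compound 2 to compound 4 (0.05 log units; within the scatter), giving an expected 0.5 h, between 0.25 h and 1 h.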

Compound 4, half-life: 0.7 h
Compound 4: the middle estimate sits 1.4-fold (0.15 log units) below what was measured, within the range that was stated.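

In this assay, hydrogen in place of methyl on an aromatic carbon of a six-membered aromatic ring of carbon only gave a 1.6-fold higher number from compound 2 to compound 4 (0.19 log units; within the scatter), whereas the same kind of change on a five-membered aromatic ring with 2 nitrogen gave an at least 15-fold higher number from compound 3 to compound 1 (1.17 log units; beyond the scatter). The large step therefore did not carry over to this second pair, but that does not show that the core alone decides its size: the two pairs differ in the place of the change as well as in the core, and neither place is tested on both cores. The value of compound 1 is a limit of the assay and not a number: the limit of > 2 h in this assay, at which 1 of the 4 values shown sits.

The compounds shown leave open what a methoxy group, a chlorine atom or a carboxylic acid would do in place of the methyl of compound 2. They also leave open whether a methyl on the ring of carbon only would matter in the core of compound 1.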